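Carboxy in place of hydrogen: solubility of compound 4

The source may hold more compounds than are shown below. What is called first, only, known or untested is meant among the compounds shown, and "the series" means these compounds.

Compound 1 `FC(F)(F)c1cccc(-c2nc3cnc(Nc4ccccn4)cc3[nH]2)c1`: 21000 nM
Compound 2 `COc1cccc(Nc2cc3[nH]c(-c4cccc(C(F)(F)F)c4)nc3cn2)n1`: 85000 nM
Compound 3 `N#Cc1ccc(Nc2cc3[nH]c(-c4cccc(C(F)(F)F)c4)nc3cn2)nc1`: < 5000 nM, a limit of the assay

In a physicochemical assay for solubility, using the shake flask method, measured as kinetic solubility, with a stated time of 20 h, at pH 2 (a higher number here means a more soluble compound, a lower number a less soluble compound), compound 1 holds the lower of the two numbers; the step of a 4.0-fold higher number from compound 1 to compound 2 (0.61 log units; beyond the scatter) separates it from compound 2. For compound 3 only the limit of < 5000 nM in this assay, at which 1 of the 3 values shown sits, is known, not a number. Compound 4 `O=C(O)c1ccnc(Nc2cc3[nH]c(-c4cccc(C(F)(F)F)c4)nc3cn2)c1` differs from compound 1 by carboxy in place of hydrogen on an aromatic carbon. Among the measured compounds shown here, no measured step makes that change; the two that alter the same ring pull in opposite directions, a 4.0-fold higher number from compound 1 to compound 2 (0.61 log units; beyond the scatter) and an at least 4.2-fold lower number from compound 1 to compound 3 (0.62 log units; beyond the scatter), so the expected step of a 1.4-fold lower number from compound 1 to compound 4 (0.15 log units; within the scatter) is modest at most. Compound 4 is estimated at 15000 nM, within 4000 nM to 60000 nM.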

Compound 4, solubility: < 5000 nM
Compound 4 ended at the assay's limit (the forecaster's own chance of this, stated with the estimate: 25%); middle value at least 3.0-fold (0.47 log units) away from the limit.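

In this assay compound 4 gives < 5000 nM, which is a limit of the assay and not a number. Carboxy opposite the ring nitrogen gives an at least 4.2-fold lower number from compound 1 to compound 4 (0.62 log units; beyond the scatter), and an at least 17-fold lower number from compound 2 to compound 4 (1.23 log units; beyond the scatter), so this change falls on the low side of the parent, far from the methoxy-bearing compound. Compound 3 and compound 4 now share one floor, and the step between them cannot be read: the limit of < 5000 nM in this assay, at which 2 of the 4 values shown sit.

From the compounds shown here alone, how far compound 4 lies beneath that limit stays open. So does whether an amine or a methyl ester opposite the ring nitrogen would also end at the limit.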